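Thiophene to furan swap on the hydrazide carbonyl

A few compounds are considered here, and "the series" means these few. Any claim that something is new, unique, unknown or untested is made for them only; others in the source may bear on it.

Going by the values given here, compound 1 `COc1ccc(C(=O)N/N=C/C2=Cc3ccccc3OC2c2ccccc2)cc1` is the only member of this series with a result in a toxicity assay on HEK-293T cells (Homo sapiens) for cytotoxicity, read by MTT assay, with a stated time of 72 h (a lower number here means a stronger inhibitor, a higher number a weaker inhibitor), where compound 1 gives 90700 nM. For compound 2 `O=C(N/N=C/C1=Cc2ccccc2OC1c1ccccc1)c1cccs1` the entry in this assay reads "not determined" (no result reported), so no number exists for compound 2 in this assay. Compound 3 `O=C(N/N=C/C1=Cc2ccccc2OC1c1ccccc1)c1ccco1` differs from compound 2 by furan-2-yl in place of thiophen-2-yl on a carbonyl carbon. Among the compounds with values here, with no measured step between any two compounds, the size of this step cannot be read from data; a shift no larger than the usual scatter is expected. Drawing on compound 1 at 90700 nM as the only anchor, compound 3 is estimated at 85000 nM, within 30000 nM to 200000 nM.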

Compound 3, half-maximal inhibitory concentration: 11900 nM
Beside the measured number, compound 3's estimate is 7.1-fold (0.85 log units) above it; the measured number lies below the stated range.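

In this assay furan-2-yl in place of 4-methoxyphenyl on a carbonyl carbon gives a 7.6-fold lower number from compound 1 to compound 3 (0.88 log units; beyond the scatter) and so shows that the read-out responds to the group at this position. The step from thiophen-2-yl to furan-2-yl cannot be read, as compound 2 has no number. Nothing at hand accounts for the size of this shift.

Still open, going by these compounds, is whether thiophen-2-yl would read closer to furan-2-yl or to 4-methoxyphenyl here. Also open, on these data alone, is how a basic amine such as piperidin-4-yl or a carboxylic acid would read at the same carbonyl carbon.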